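Phthalimidooxy esters: shortening the ester chain

A few compounds are considered here, and "the series" means these few. Any claim that something is new, unique, unknown or untested is made for them only; others in the source may bear on it.

Compound 2 `CCCCCOC(=O)C(C)ON1C(=O)c2ccccc2C1=O` gives 64% in a functional assay on the whole organism for inhibition, with Lepidium sativum as the target, tested at 1 ppm (on this read-out lower numbers stand for less inhibition of growth and higher numbers for more inhibition of growth at the one concentration tested), the higher of the two numbers in hand; compound 1 `CCOC(=O)C(CC)ON1C(=O)c2ccccc2C1=O` gives 0% in this assay, a gap beyond the scatter. Compound 3 `CCOC(=O)C(C)ON1C(=O)c2ccccc2C1=O` is not yet measured; it differs from compound 2 by hydrogen in place of propyl on a saturated chain carbon, two bonds along the chain from an oxygen next to a carbonyl group. For the measured compounds named here, no measured pair shows this change, so its size is open; the two numbers in hand differ in two places at once, and compound 1 sits at the low end. A downward step from compound 2 is expected, a number 39 percentage points lower from compound 2 to compound 3 (beyond the scatter) in this assay. For compound 3 the estimate is 25%, within 0% to 60%.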

Compound 3, percent growth inhibition at one concentration: 68%
Compound 3: the middle estimate sits 43 percentage points below what was measured, and the stated range ends below it.
By their numbers in this assay, from the lowest: compound 1; then compounds 2 and 3 (each within the scatter of the next).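

Pentyl to ethyl on the ester costs nothing measurable, with a number 4 percentage points higher from compound 2 to compound 3 (within the scatter) in this assay, so the ester chain length seen in these two compounds does not separate them. The large step lies instead at the other chain: hydrogen in place of methyl on a saturated chain carbon, two bonds along the chain from a carbonyl carbon and an oxygen on an unsaturated carbon, gives a number 68 percentage points higher from compound 1 to compound 3 (beyond the scatter) in this assay and accounts for the low end of the series. Nothing measured here explains the size of either step.

Still open, going by these compounds, is whether a longer chain than pentyl on the ester holds the read-out. A carboxylic acid in place of the ester is equally untested by the compounds shown.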